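Bromo for Cyano: Expected Cytotoxicity of Compound 3

The source may hold more compounds than are shown below. What is called first, only, known or untested is meant among the compounds shown, and "the series" means these compounds.

Compound 1, `Cc1ccc(OCCCCCn2ccc(=O)[nH]c2=O)cc1`: in an ADME assay on HEL cells (Homo sapiens) for cytotoxicity (on this read-out lower numbers stand for higher toxicity in this test and higher numbers for lower toxicity in this test), compound 1 gives > 100000 nM, which is a limit of the test rather than a number.
Compound 2, `N#Cc1ccc(OCCCCCn2ccc(=O)[nH]c2=O)cc1`: in this assay compound 2 gives 100000 nM.

Going by the values given here, compound 2 thus holds the only number recorded in this assay; the other value is a limit. Among the compounds with values here, the single measured step, a number no higher from compound 1 to compound 2 (the limit leaves the size open), runs from that limit to the number, so its size cannot be read, as the limit of > 100000 nM in this assay, at which 1 of the 2 values shown sits, sits at one end.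

Compound 3, `O=c1ccn(CCCCCOc2ccc(Br)cc2)c(=O)[nH]1`, differs from compound 2 by bromo in place of cyano on an aromatic carbon. Within the data shown here, no measured step covers a bromo-for-cyano exchange, and the one measured step gives no readable size, so there is no basis to expect a change beyond the usual scatter. For compound 3 the estimate is 100000 nM, with a range from 30000 nM to 200000 nM. The expected step of no change at the digits printed from compound 2 to compound 3 (within the scatter) is essentially flat, and a limit rather than a number is quite possible.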

Compound 3, half-maximal cytotoxic concentration: > 100000 nM
Compound 3: a limit, no number; the forecaster's own chance of this, stated with the estimate: 50%; the middle value lies on the limit itself.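

In this assay compound 3 gives > 100000 nM, which is a limit and not a number. Bromo in place of cyano gives a number no lower from compound 2 to compound 3 (the limit leaves the size open), and neither this step nor the step from the methyl compound to the bromo compound has a size that can be read. What is new is that a halogen on this aromatic carbon also leaves the read-out at the end of the test's range, joining methyl there: the limit of > 100000 nM in this assay, at which 2 of the 3 values shown sit.

The compounds shown leave open whether any group at this place gives a clearly lower number than compound 2, at 100000 nM. An amine or a carboxylic acid at this place, or a longer chain, could show whether toxicity in this test appears at all in this series.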